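Replacing a hydroxymethyl with an azidomethyl on a quinoline-like core

The source may hold more compounds than are shown below. What is called first, only, known or untested is meant among the compounds shown, and "the series" means these compounds.

Compound 1, whose structure is `OCc1cc2ccccc2nc1-c1ccccc1O`, was tested in a functional assay on COLO 205 cells (Homo sapiens) for cytotoxicity, read by MTT assay, with a stated time of 24 h (on this read-out lower numbers stand for stronger inhibition and higher numbers for weaker inhibition), and here compound 1 gives 40000 nM. Within the numbers shown this is the only true value; the other result is a limit rather than a number. Compound 2 `Cc1ccc2nc(-c3ccccc3O)c(CO)cc2c1` carries an added methyl on an aromatic carbon of the shared core. In this assay compound 2 reaches only > 100000 nM, which is a limit of the assay and not a measured number. The step of an at least 2.5-fold higher number from compound 1 to compound 2 (0.39 log units; beyond the scatter) therefore rests on the limit of > 100000 nM in this assay, at which 1 of the 2 values shown sits, and says only that adding the methyl weakened the effect by at least that much.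

Compound 3 `[N-]=[N+]=NCc1cc2ccccc2nc1-c1ccccc1O` differs from compound 1 in another place: azido in place of hydroxy on a saturated chain carbon bound to an aromatic carbon. Among the measured compounds shown here, no measured step touches this change, so the one step recorded, which concerns a methyl elsewhere, does not bear on it and no direction can be argued from the data. The expectation is therefore a step of about no change at the digits printed from compound 1 to compound 3 (within the scatter), within the scatter. Compound 3 is estimated at 40000 nM in this assay, with a range from 13000 nM to 120000 nM.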

Compound 3, half-maximal inhibitory concentration: 19000 nM
Estimate against measurement, compound 3: 2.1-fold (0.32 log units) above; the measured number falls inside the stated range.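

Changing hydroxymethyl to azidomethyl on the shared core gives a 2.1-fold lower number from compound 1 to compound 3 (0.32 log units; beyond the scatter) in this assay. Among the compounds shown here, this shows that the group on a saturated chain carbon bound to an aromatic carbon can influence the read-out, and that this change moves it modestly towards stronger inhibition, whereas the only earlier step concerned a methyl elsewhere on the core and went towards weaker inhibition. The hydroxy that leaves counts as a hydrogen-bond donor and the azido that enters does not, so the donor on this particular hydroxy is not required for the effect seen with compound 3, but nothing measured here explains why the number falls.

Two compounds at this place cannot show whether the lower number is special to azido, or whether an amine, a carboxylic acid or a longer chain in its stead would lower the number further, leave it unchanged or raise it. Also open, on these data alone, is how azidomethyl would behave on the methyl-bearing core of compound 2, whose result of > 100000 nM is a limit.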